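Second hydroxy added to the chalcone of compound 1

The compounds below may be only part of what the source reports. "The series", "measured", "known", "first", "only" and "open" are said of these compounds alone.

Measured compounds:
compound 1 `COc1ccccc1/C=C/C(=O)c1cccc(O)c1` — 20000 nM
compound 2 `COc1ccc2c(c1)OCC(C(=O)c1cc(O)ccc1O)=C2` — 3980 nM

Of the compounds shown here, two have been measured in an assay on HEK-293T cells for antagonist activity at Bile acid receptor (Homo sapiens), read by a luciferase reporter, with a stated time of 24 h; on this read-out higher numbers stand for weaker inhibition and lower numbers for stronger inhibition. Compound 1 `COc1ccccc1/C=C/C(=O)c1cccc(O)c1` gives 20000 nM, the higher of the two numbers. Compound 2 `COc1ccc2c(c1)OCC(C(=O)c1cc(O)ccc1O)=C2` gives 3980 nM in this assay, a lower number than compound 1 by a margin that lies beyond the usual scatter; the two structures differ in several places at once, so no single step can be read from this pair.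

The next compound, compound 3 `COc1ccccc1/C=C/C(=O)c1cccc(O)c1O`, is not yet measured. It differs from compound 1 in one place: hydroxy in place of hydrogen on an aromatic carbon. Compound 2 also carries two hydroxy groups on its ketone-bearing ring and gives the lower number, but it differs from compound 1 elsewhere too, so nothing firm follows for compound 3. A step of moderate size toward a lower number is expected, since compound 1 starts from 20000 nM and has room to move. The step from compound 1 to compound 3 in this assay is estimated at a 2.5-fold lower number from compound 1 to compound 3 (0.40 log units; beyond the scatter). For compound 3 the estimate in this assay is 8000 nM, with a range from 2500 nM to 25000 nM.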

Compound 3, half-maximal inhibitory concentration: 16200 nM
Compound 3: middle estimate off by 2.0-fold (0.31 log units), on the low side; low and high end bracket the measured number.
By their numbers in this assay, from the lowest: compound 2; then compounds 3 and 1 (each within the scatter of the next).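

In this assay, within the data shown here, hydroxy in place of hydrogen on this aromatic carbon, ortho to a hydroxy group and ortho to a large group, gives a 1.2-fold lower number from compound 1 to compound 3 (0.09 log units; within the scatter), the first reading of a single change. At this position, then, the added hydroxy does not separate the two compounds on this read-out: compound 1 and compound 3 stand within the scatter of each other, and no effect of the change can be claimed from this pair. Nothing measured here bears on why this position responds as it does.

The compounds shown leave open whether a different group on this same carbon, such as an amine, a carboxylic acid or a fluorine atom, would give a step beyond the scatter. They also leave open which structural feature accounts for the number of compound 2, at 3980 nM, since that compound differs from compound 1 and from compound 3 in several places at once and no single step to it can be read.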